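Ethyl to cyclopentyl: compound 3 to compound 4

This account rests on a few compounds, and the source may have more. Where it says the series, first, only, none or still open, it means among the compounds named here.

Compound 3 (`CCC(Oc1ccc(-n2cc(C(F)(F)F)cn2)cc1)c1ccc(C(=O)NCCC(=O)O)cc1`) gives 1.9 in a physicochemical assay for lipophilicity, using the shake flask method, at pH 7.4 (a lower number here means a more polar compound, a higher number a more lipophilic compound), and lies within the scatter of compound 1 (`O=C(O)CCNC(=O)c1ccc(C(Oc2ccc(-n3cc(C(F)(F)F)cn3)cc2)C2CC2)cc1`) at 1.7 while compound 2 (`O=C(O)CCNC(=O)c1ccc(C(Oc2ccc(-n3cc(C(F)(F)F)cn3)cc2)C2CCC2)cc1`) gives 2.6 on the same scale. Compound 4 (`O=C(O)CCNC(=O)c1ccc(C(Oc2ccc(-n3cc(C(F)(F)F)cn3)cc2)C2CCCC2)cc1`) has cyclopentyl in place of ethyl (cyclopentyl in place of ethyl on a saturated chain carbon bound to an aromatic carbon and an oxygen on an aromatic ring) on a saturated chain carbon bound to an aromatic carbon and an oxygen on an aromatic ring. Within the data shown here, the closest precedent is ethyl in place of cyclobutyl (a number 0.70 log units lower from compound 2 to compound 3 (beyond the scatter)) and is modest and beyond the scatter. Cyclobutyl in place of cyclopropyl (a number 0.90 log units higher from compound 1 to compound 2 (beyond the scatter)) is similar in size, whereas ethyl in place of cyclopropyl (a number 0.20 log units higher from compound 1 to compound 3 (within the scatter)) stays within the scatter. A modest rise beyond the scatter is therefore expected, estimated as a number 1.00 log units higher from compound 3 to compound 4 (beyond the scatter) in this assay for this change. For compound 4 the estimate is 2.9 with 2.4 to 3.4 as the expected range.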

Compound 4, distribution coefficient: 3.3
Estimate against measurement, compound 4: 0.40 log units below; measured number inside the range.
By their numbers in this assay, from the lowest: compounds 1 and 3 (each within the scatter of the next); then compound 2; then compound 4.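

In this assay, cyclopentyl on this carbon stands above all three earlier groups, with a number 1.40 log units higher from compound 3 to compound 4 (beyond the scatter), a number 0.70 log units higher from compound 2 to compound 4 (beyond the scatter) and a number 1.60 log units higher from compound 1 to compound 4 (beyond the scatter). Across compound 1, compound 2 and compound 4 the number now rises with each larger carbon ring, a trend resting on these three rings alone. Compound 3, with its open ethyl chain, stands outside this ring series and lies within the scatter of compound 1.

From the compounds shown here alone, whether the rise continues with cyclohexyl, or holds for a ring carrying an ether oxygen or an amine, remains open. Nothing shown gives a cause for these steps.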